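A few compounds are considered here, and "the series" means these few. Any claim that something is new, unique, unknown or untested is made for them only; others in the source may bear on it.

Compound 1 `Cn1nc2c(=O)n(CC3(O)CCN(Cc4ccc(-c5cccs5)cc4Cl)CC3)cnc2c1-c1ccc(CN)cc1` gives 38.6 nM in an assay on isolated protein for inhibition of ubiquitin carboxyl-terminal hydrolase 7 (Homo sapiens), with stated times of 30 min and 2 h; a higher number here means a weaker inhibitor, a lower number a stronger inhibitor; compound 2 `CC(=O)NCc1ccc(-c2c3ncn(CC4(O)CCN(Cc5ccc(-c6ccco6)cc5Cl)CC4)c(=O)c3nn2C)cc1` gives 46.1 nM; compound 3 `CCNCc1ccc(-c2c3ncn(CC4(O)CCN(Cc5ccc(-c6ccco6)cc5Cl)CC4)c(=O)c3nn2C)cc1` gives 15.2 nM.

Among these three numbers compound 1 stands second highest: compound 2 lies within the scatter of it, while compound 3 sits beyond the scatter below it. Compound 4 `Cn1nc2c(=O)n(CC3(O)CCN(Cc4ccc(-c5ccsc5Cl)cc4Cl)CC3)cnc2c1-c1ccc(CN)cc1` differs from compound 1 in one place: 2-chlorothiophen-3-yl in place of thiophen-2-yl on an aromatic carbon. Going by the values given here, the only measured step, a 3.0-fold lower number from compound 2 to compound 3 (0.48 log units; beyond the scatter), concerns a substituent on an amine nitrogen and does not bear on this exchange of one aromatic group for another. Among the compounds with values here, with no step informing the change, no movement beyond the scatter is expected in this assay. Compound 4 is therefore estimated at 40 nM, with a range of 15 nM to 110 nM, and the step of a 1.0-fold higher number from compound 1 to compound 4 (0.02 log units; within the scatter) is expected to stay within the scatter.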

Compound 4, half-maximal inhibitory concentration: 453 nM
Compound 4: middle estimate off by 11-fold (1.05 log units), on the low side, and the stated range ends below it.
By their numbers in this assay, from the lowest: compound 3; then compounds 1 and 2 (each within the scatter of the next); then compound 4.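

In this assay, going by these compounds alone, 2-chlorothiophen-3-yl in place of thiophen-2-yl gives a 12-fold higher number from compound 1 to compound 4 (1.07 log units; beyond the scatter), the first measured step at this place, meta to a chloro group and para to a large group. The number thus responds strongly to this exchange, even though both groups are five-membered aromatic rings with one hetero atom and the same hydrogen-bond counts. Nothing available accounts for the size of this step.

The compounds shown do not separate the added chlorine from the changed point of attachment, as neither change appears alone. As far as these compounds go, how a plain thiophen-3-yl or a phenyl would fare at this place also remains open.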